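The compounds below may be only part of what the source reports. "The series", "measured", "known", "first", "only" and "open" are said of these compounds alone.

Compound 1 `COc1cc2cc(Oc3ccc(NC(=O)Nc4cccc(C(F)(F)F)c4)cc3)c(C)nc2cc1OC`: 36100 nM
Compound 2 `COc1cc2cc(Oc3ccc(NC(=O)Nc4ccc(Cl)c(C(F)(F)F)c4)cc3)c(C)nc2cc1OC`: 13800 nM

For the measured compounds named here, in a functional assay on KM12 cells (Homo sapiens) for inhibition, read by sulforhodamine B assay, with a stated time of 48 h (a higher number here means that more compound is tolerated, a lower number that less compound is tolerated), compound 2 gives the lower of the two numbers, and the only measured step, a 2.6-fold lower number from compound 1 to compound 2 (0.42 log units; beyond the scatter), separates it from compound 1. Compound 3 `COc1cc2cc(Oc3ccc(NC(=O)Nc4ccc(Cl)c(Cl)c4)cc3)c(C)nc2cc1OC` differs from compound 2 by chloro in place of trifluoromethyl on an aromatic carbon. Going by the values given here, no measured step swaps a trifluoromethyl for a chloro, so that step bears only loosely on the question; it shows that a small change on this ring can move the number modestly. The change from compound 2 to compound 3 is expected to stay within the scatter, with a 1.1-fold higher number from compound 2 to compound 3 (0.04 log units; within the scatter). Compound 3 is therefore estimated at 15000 nM, between 6000 nM and 38000 nM.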

Compound 3, concentration lethal to 50% of the cells: 74700 nM
Compound 3: middle estimate off by 5.0-fold (0.70 log units), on the low side; measured number outside the range, above it.
By their numbers in this assay, from the lowest: compound 2; then compound 1; then compound 3.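

In this assay, this position responds more strongly than the earlier step suggested: chloro in place of trifluoromethyl gives a 5.4-fold higher number from compound 2 to compound 3 (0.73 log units; beyond the scatter), a larger move than a 2.6-fold lower number from compound 1 to compound 2 (0.42 log units; beyond the scatter). Compound 3 also ends above compound 1, with a 2.1-fold higher number from compound 1 to compound 3 (0.32 log units; beyond the scatter), so among these compounds the lowest number goes with chloro and trifluoromethyl together on the ring. Nothing available here accounts for this change.

Going by these compounds, whether a nitrile or an amine at this position would give a number closer to that of compound 2 or compound 3 remains open.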